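A few compounds are considered here, and "the series" means these few. Any claim that something is new, unique, unknown or untested is made for them only; others in the source may bear on it.

Working notes on the series.

Of the compounds shown here, two of this core have been measured so far. Compound 1 `O=C1NC(=S)S/C1=C\c1ccc(OCN2C(=O)c3ccccc3C2=O)cc1` gives 7910 nM in an assay on isolated protein for inhibition of Alpha glucosidase (Homo sapiens), read by spectrophotometry, with stated times of 15 min and 30 min; a lower number here means a stronger inhibitor, a higher number a weaker inhibitor. Compound 2 `O=C1NC(=S)S/C1=C\c1ccc(OCN2C(=O)c3ccccc3C2=O)c([N+](=O)[O-])c1`, which carries a nitro in place of hydrogen on an aromatic carbon, gives 6590 nM in this assay. Within the data shown here, the only step measured to date, a 1.2-fold lower number from compound 1 to compound 2 (0.08 log units; within the scatter), shows that adding the nitro left the number where it was as far as the scatter allows one to say. Compound 2 thus holds the lower of the two numbers in this assay, with compound 1 within the scatter of it, so neither can be called stronger than the other.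

Compound 3 `O=C1NC(=S)S/C1=C\c1ccc(OCN2C(=O)c3ccccc3C2=O)c(Cl)c1` is the next member. Its change from compound 2 is chloro in place of nitro on an aromatic carbon. Among the measured compounds shown here, no measured step exchanges one group for another on this ring; the single step that bears on the position, a 1.2-fold lower number from compound 1 to compound 2 (0.08 log units; within the scatter), was within the scatter, which gives no reason to expect the chloro to move the number beyond the scatter either. Compound 3 is therefore estimated at 7000 nM in this assay, with a range of 3500 nM to 14000 nM. The expected step of a 1.1-fold higher number from compound 2 to compound 3 (0.03 log units; within the scatter) would itself sit within the scatter.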

Compound 3, half-maximal inhibitory concentration: 5440 nM
For compound 3 the middle estimate is 1.3-fold (0.11 log units) above the measured one; measured number inside the range.
By their numbers in this assay, from the lowest: compounds 3, 2 and 1 (each within the scatter of the next).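

In this assay, chloro in place of nitro on this aromatic carbon, ortho to a large group, gives a 1.2-fold lower number from compound 2 to compound 3 (0.08 log units; within the scatter) and chloro in place of hydrogen gives a 1.5-fold lower number from compound 1 to compound 3 (0.16 log units; within the scatter), so the comparison now covers a replacement of one substituent by another as well as two additions to the unsubstituted ring. Hydrogen, a nitro of 3 heavy atoms and a chloro of 1 heavy atom all leave the number within the scatter at this position, and the hydrogen-bond acceptors that leave with the nitro make no difference that can be read here. The data at hand give no explanation for this flat result.

Going by these compounds, whether any group at this position can move the number beyond the scatter remains open, and an amine, a carboxylic acid or a longer chain such as ethoxy would each put that to the test. The compounds shown also keep the rest of the shared core fixed, so what its other parts contribute, and whether nitro or chloro would behave alike elsewhere on the ring, stays unknown.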